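The source may report more compounds than this note shows. Statements on the series, on what has been measured and on what is new or still open speak of the compounds shown alone.

Measured so far in a functional assay on HCT-116 cells (Homo sapiens) for inhibition, read by MTT assay, with a stated time of 72 h; a lower number here means a stronger inhibitor of growth, a higher number a weaker inhibitor of growth
- compound 1 `NNC(=O)CCc1ccncc1-c1ccc2ccccc2c1` gives > 30000 nM (a limit)
- compound 2 `CCOC(=O)/C=C/c1ccncc1-c1ccc2ccccc2c1` gives 910 nM
- compound 3 `COC(=O)/C=C/c1ccncc1-c1ccc2ccccc2c1` gives 350 nM

Going by the values given here, compound 3 has the lowest of the two exact numbers, and the gap to its only exact neighbour is modest, a 2.6-fold lower number from compound 2 to compound 3 (0.41 log units; beyond the scatter). The value of compound 1 is only a limit, (the limit of > 30000 nM in this assay, at which 1 of the 3 values shown sits).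

Compound 4 `O=C(O)CCc1ccncc1-c1ccc2ccccc2c1` keeps the shared core but carries 2-carboxyethyl in place of 2-(methoxycarbonyl)ethenyl on an aromatic carbon. Like compound 1, it loses the ethenyl chain and the ester. Among the compounds with values here, the steps that bear on this are both large, an at least 85-fold lower number from compound 1 to compound 3 (1.93 log units; beyond the scatter) and an at least 32-fold lower number from compound 1 to compound 2 (1.51 log units; beyond the scatter), though they also change the end group. Read in reverse, they suggest a large move towards a higher number in this assay, while the different end group leaves room for an exact value. The expected change is a 34-fold higher number from compound 3 to compound 4 (1.54 log units; beyond the scatter). For compound 4 the estimated value is 12000 nM, with an expected range from 3000 nM to 40000 nM.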

Compound 4, concentration for 50% growth inhibition: > 30000 nM
Compound 4: only a limit was reported; the forecaster's own chance of this, stated with the estimate: 40%; middle value at least 2.5-fold (0.39 log units) away from the limit.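

Swapping the 2-(methoxycarbonyl)ethenyl group for 2-carboxyethyl on this aromatic carbon gives an at least 85-fold higher number from compound 3 to compound 4 (1.93 log units; beyond the scatter), and swapping the ethyl ester counterpart gives an at least 32-fold higher number from compound 2 to compound 4 (1.51 log units; beyond the scatter). The large rise seen earlier with the 2-(aminocarbamoyl)ethyl chain of compound 1 is therefore not tied to that one end group: both saturated chains shown, with different ends, give only limits, while both ethenyl esters give exact values. The step between compound 1 and compound 4 cannot be read, as each value is only a limit: the limit of > 30000 nM in this assay, at which 2 of the 4 values shown sit.

Each readable step changes the chain and its end group together, so the compounds shown do not tell which change matters. A saturated methyl ester, 2-(methoxycarbonyl)ethyl, and an unsaturated carboxylic acid, 2-carboxyethenyl, would separate the two.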